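The source may hold more compounds than are shown below. What is called first, only, known or untested is meant among the compounds shown, and "the series" means these compounds.

In a functional assay on HT cells (Homo sapiens) for antiproliferative activity, read by fluorescence, with a stated time of 72 h (on this read-out lower numbers stand for stronger inhibition of growth and higher numbers for weaker inhibition of growth), compound 3 (`CC(C)c1n[nH]c2c(NCc3ccc(-c4ccccn4)cc3)nc(S)nc12`) gives the highest number of the three measured compounds (2760 nM), so it holds back cell growth least among them. Compound 3 has only a hydrogen on the sulfur of the shared core, whereas its two relatives carry a chain there. With 2-carbamoylethyl on that sulfur, compound 1 (`CC(C)c1n[nH]c2c(NCc3ccc(-c4ccccn4)cc3)nc(SCCC(N)=O)nc12`) reads lower (120 nM). With 2-ureidoethyl in the same place, compound 2 (`CC(C)c1n[nH]c2c(NCc3ccc(-c4ccccn4)cc3)nc(SCCNC(N)=O)nc12`) also reads lower (240 nM).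

The next step leads to compound 4 (`CC(=O)NCCSc1nc(NCc2ccc(-c3ccccn3)cc2)c2[nH]nc(C(C)C)c2n1`), with 2-acetamidoethyl in place of hydrogen on a sulfur. Among the compounds with values here, two measured steps bear on this change, although they run in the opposite direction, from chain to hydrogen. They are a 23-fold higher number from compound 1 to compound 3 (1.36 log units; beyond the scatter) and a 12-fold higher number from compound 2 to compound 3 (1.06 log units; beyond the scatter) and both are large. The two chains themselves differ by a 2.0-fold higher number from compound 1 to compound 2 (0.30 log units; within the scatter) and so cannot be told apart in this measurement.

Adding a third chain of this kind to compound 3 is therefore expected to lower the number in this assay by a large step of similar size. The expected change is a 14-fold lower number from compound 3 to compound 4 (1.14 log units; beyond the scatter) and it rests on only two chains, so the range stays wide. The estimate for compound 4 is 200 nM (expected range 80 nM to 500 nM).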

Compound 4, concentration for 50% growth inhibition: 71 nM
The estimate for compound 4 lay 2.8-fold (0.45 log units) above the measured number; measured number below the stated range.
By their numbers in this assay, from the lowest: compounds 4, 1 and 2 (each within the scatter of the next, the first and the last beyond it); then compound 3.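

In this assay, a third chain on the sulfur again brings a large step, a 39-fold lower number from compound 3 to compound 4 (1.59 log units; beyond the scatter), so the lower number now holds for all three chains shown. Within the data shown here, the chains can also now be told apart for the first time: a 3.4-fold lower number from compound 2 to compound 4 (0.53 log units; beyond the scatter) is a modest step beyond the scatter, although a 1.7-fold lower number from compound 1 to compound 4 (0.23 log units; within the scatter) stays within it, as does the earlier 2.0-fold higher number from compound 1 to compound 2 (0.30 log units; within the scatter). The amino group at the chain end in compounds 1 and 2 is also not needed for a low number, since compound 4 carries methyl on that carbonyl carbon and still reads 71 nM.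

Nothing shown here gives a reason for these steps. Every chain shown has two saturated carbons after the sulfur and ends in a carbonyl group, so it remains open whether a plain ethyl, a chain ending in an amine, a chain ending in a carboxylic acid or a longer chain would give a similarly low number.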